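The compounds below may be only part of what the source reports. "The series", "measured", "known", "first", "only" and "open" are said of these compounds alone.

Measured so far in an ADME assay on microsomes from liver (Mus musculus) for metabolic stability; on this read-out lower numbers stand for a shorter-lived compound and higher numbers for a longer-lived compound:
compound 1 `CC1(C(=O)NCCSc2nonc2/C(=N/O)Nc2ccc(F)c(C(F)F)c2)CCN1` gives 0.268 h
compound 2 `NS(=O)(=O)CC(=O)NCCSc1nonc1/C(=N/O)Nc1ccc(F)c(Br)c1` gives 1.12 h
compound 3 `CS(=N)(=O)CC(=O)NCCSc1nonc1/C(=N/O)Nc1ccc(F)c(Br)c1` gives 1.25 h

Compound 1 stands lowest of the three, and its value lies beyond the scatter from both of the others. Among the compounds with values here, compound 4 `CS(=O)(=O)CC(=O)NCCSc1nonc1/C(=N/O)Nc1ccc(F)c(C(F)F)c1` has no measurement yet. It differs from compound 1 in one place: a group of 5 heavy atoms (2 carbon, 2 oxygen, 1 sulfur; no ring) in place of a group of 5 heavy atoms (4 carbon, 1 nitrogen; one four-membered non-aromatic ring with 1 hetero atom), on a carbonyl carbon. The group that enters has no ring, and it sits on a carbonyl carbon.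

Within the data shown here, only one measured step bears on this directly. The step of a 1.1-fold higher number from compound 2 to compound 3 (0.05 log units; within the scatter) is a swap on a saturated chain carbon bound to a carbonyl carbon, and it stays within the scatter. It does not test the loss of the four-membered ring. Compound 2 and compound 3 also have no ring in that group, but they differ from compound 1 in more than one place, so this evidence is indirect. Even so, a rise toward them is expected. The expected step is a 3.7-fold higher number from compound 1 to compound 4 (0.57 log units; beyond the scatter), which would lie beyond the scatter. Compound 4 is estimated at 1 h, with an expected range from 0.45 h to 2.2 h.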

Compound 4, half-life: 0.765 h
For compound 4 the middle estimate is 1.3-fold (0.12 log units) above the measured one; the range from low to high includes it.
By their numbers in this assay, from the lowest: compound 1; then compounds 4, 2 and 3 (each within the scatter of the next).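

In this assay, within the data shown here, the swap of the four-membered ring group for (methylsulfonyl)methyl on the carbonyl carbon gives a 2.9-fold higher number from compound 1 to compound 4 (0.46 log units; beyond the scatter) and is the first change at this position measured with the rest of the molecule held constant. Among these compounds, the only earlier step, a 1.1-fold higher number from compound 2 to compound 3 (0.05 log units; within the scatter), concerned a group one carbon further out and stayed within the scatter, whereas this change at the carbonyl carbon lies beyond it. Nothing among the data shown accounts for this rise.

The compounds shown do not separate the loss of the ring from the entry of the (methylsulfonyl)methyl group, and an open-chain amine or a carboxylic acid at this place would help to tell these apart. They also leave open whether the same swap gives a similar step with bromine on the aromatic ring.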